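Cyclohexyl to phenyl on an amide-type nitrogen

The compounds below may be only part of what the source reports. "The series", "measured", "known", "first", "only" and "open" are said of these compounds alone.

Measured so far in a functional assay on HepG2 cells (Homo sapiens) for antiproliferative activity, read by MTT assay, with a stated time of 72 h; a higher number here means a weaker inhibitor, a lower number a stronger inhibitor:
Compound 1 `COc1cccc(N2C(=O)COc3ccc(-c4cnc(OC)c(NS(=O)(=O)c5ccc(F)cc5)c4)cc32)c1`: > 40000 nM (a limit)
Compound 2 `COc1ncc(-c2ccc3c(c2)N(C2CCCCC2)C(=O)CO3)cc1NS(=O)(=O)c1ccc(F)cc1`: > 40000 nM (a limit)

Compound 2 has no exact number, only the limit > 40000 nM. Both compounds sit at the limit of > 40000 nM in this assay, at which 2 of the 2 values shown sit. Compound 3 `COc1ncc(-c2ccc3c(c2)N(c2ccccc2)C(=O)CO3)cc1NS(=O)(=O)c1ccc(F)cc1` has phenyl in place of cyclohexyl on an amide-type nitrogen in a ring. Within the data shown here, the one measured step at this nitrogen, a step that the two limits leave unreadable from compound 1 to compound 2, offers no size to carry over. Compound 1, with 3-methoxyphenyl on that nitrogen, also gives only a limit, > 40000 nM. Neither group yielded a number, so a reading at the limit is expected again in this assay, with no readable direction. The expected step is a step that the limit leaves unreadable from compound 2 to compound 3. For compound 3 the estimate is 45000 nM, expected to fall between 15000 nM and 100000 nM.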

Compound 3, half-maximal inhibitory concentration: 14000 nM
Estimate against measurement, compound 3: 3.2-fold (0.51 log units) above, and the stated range ends above it.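

In this assay, phenyl in place of cyclohexyl on this amide-type nitrogen gives an at least 2.8-fold lower number from compound 2 to compound 3 (0.45 log units; beyond the scatter). Hydrogen in place of methoxy on an aromatic carbon gives an at least 2.8-fold lower number from compound 1 to compound 3 (0.45 log units; beyond the scatter), so the unsubstituted phenyl ring gives a measurable reading where cyclohexyl and 3-methoxyphenyl do not. Only compound 3 has an exact number, and the true size of each step stays unknown: the limit of > 40000 nM in this assay, at which 2 of the 3 values shown sit.

As far as these compounds go, whether a methyl group or a fluorine on the phenyl ring would lower the number further remains open. So does the effect of a pyridyl ring on this nitrogen.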